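Amide substituent swap on the aminonaphthyridine carboxamide core

This account rests on a few compounds, and the source may have more. Where it says the series, first, only, none or still open, it means among the compounds named here.

Compound 1 `Nc1ncc(C(=O)N[C@H]2C[C@@H](O)C2)c2ccc(-c3cccc(F)c3)nc12` is the reference point of this pair of notes. For the measured compounds named here, in an assay on isolated protein for inhibition of mitogen-activated protein kinase kinase kinase kinase 4 (Homo sapiens), read by Z'-LYTE (a higher number here means a weaker inhibitor, a lower number a stronger inhibitor), compound 1 gives 3.7 nM, the lowest of the two numbers so far. Going by the values given here, its nearest neighbour, compound 2 `N#CCNC(=O)c1cnc(N)c2cc(-c3cccc(F)c3)ccc12`, gives 46 nM in this assay, a higher number and a gap beyond the usual scatter; the two differ in more than one place, so no single step is drawn between them.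

Compound 3 `CNC(=O)N1CC(NC(=O)c2cnc(N)c3nc(-c4cccc(F)c4)ccc23)C1` has not yet been measured in this assay. Relative to compound 1 the change is 1-(methylcarbamoyl)azetidin-3-yl in place of 3-hydroxycyclobutyl on an amide-type nitrogen. The leaving and entering groups each carry one hydrogen-bond donor and one hydrogen-bond acceptor, while the entering group is larger and brings an amide-type carbonyl in place of a hydroxyl-bearing ring. Among the compounds with values here, no measured pair reports this change, so the step size rests on expectation only: a small loss in this assay, possibly none beyond the scatter. The step of a 2.2-fold higher number from compound 1 to compound 3 (0.33 log units; beyond the scatter) is the estimate. Compound 3 is expected to give 8 nM in this assay, within a range of 2 nM to 30 nM.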

Compound 3, half-maximal inhibitory concentration: 1.6 nM
Compound 3: middle estimate off by 5.0-fold (0.70 log units), on the high side; measured number below the stated range.
By their numbers in this assay, from the lowest: compound 3; then compound 1; then compound 2.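

In this assay, the amide-type nitrogen of the shared core tolerates a larger group: 1-(methylcarbamoyl)azetidin-3-yl in place of 3-hydroxycyclobutyl gives a 2.3-fold lower number from compound 1 to compound 3 (0.36 log units; beyond the scatter). For the compounds shown here, this is the first single-place step at this position, and it shows that neither the hydroxyl nor the defined stereocentres of compound 1 are needed for a low number, as compound 3 carries neither and still has the same count of hydrogen-bond donors and acceptors. Nothing available explains the modest gain, and no supporting measurement bears on it.

From the compounds shown here alone, whether the step comes from the azetidine ring or from the methylcarbamoyl group stays open, and an acetyl group or a methyl carbamate on the same ring nitrogen, or the unsubstituted azetidine amine, would help separate the two contributions. Also open, going by these compounds, is whether the order of compound 3 and compound 1 holds beyond this assay, since a single read-out on isolated protein says nothing about other kinases or about behaviour in cells.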